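From Compound 3 to Compound 4: An Untested Change

A few compounds are considered here, and "the series" means these few. Any claim that something is new, unique, unknown or untested is made for them only; others in the source may bear on it.

compound 1 `CCCS(=O)(=O)N1CC=C(c2ccc3c(c2)CC(C2CCN(C(=O)OC(C)C)CC2)O3)CC1`: 61%
compound 2 `CCCS(=O)(=O)N1CC=C(c2ccc3c(c2)CC(C2CCN(c4ncc(C5CC5)cn4)CC2)O3)CC1`: 85%
compound 3 `CCCc1cnc(N2CCC(C3Cc4cc(C5=CCN(S(=O)(=O)CCC)CC5)ccc4O3)CC2)nc1`: 107%

In a functional assay on HEK293 cells with Glucose-dependent insulinotropic receptor (Homo sapiens) as the target, read by cAMP accumulation, with a stated time of 60 min (on this read-out lower numbers stand for smaller maximal responses and higher numbers for larger maximal responses), compound 3 gives 107%, the highest of the three numbers. Its nearest neighbour is compound 2, and the step of a number 22 percentage points higher from compound 2 to compound 3 (beyond the scatter) lies beyond the scatter, as does a number 46 percentage points higher from compound 1 to compound 3 (beyond the scatter). The third step, a number 24 percentage points higher from compound 1 to compound 2 (beyond the scatter), sits on the same amine nitrogen in a ring. All three measured steps therefore alter one end of the shared core, while the other end stays the same throughout.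

Compound 4 `CCCc1cnc(N2CCC(C3Cc4cc(-c5ccc(S(C)(=O)=O)cc5F)ccc4O3)CC2)nc1` changes that other end: a group of 11 heavy atoms (7 carbon, 2 oxygen, 1 fluorine, 1 sulfur; one six-membered aromatic ring of carbon only) in place of a group of 12 heavy atoms (8 carbon, 1 nitrogen, 2 oxygen, 1 sulfur; one six-membered non-aromatic ring with 1 hetero atom), on an aromatic carbon. Going by the values given here, no measured step touches this position, so none of them bears on the change; the three measured compounds carry the same group there. The expectation for compound 4 thus rests on compound 3 alone, and the direction of any step cannot be read from the data. Compound 4 is expected to show a step of a number 12 percentage points lower from compound 3 to compound 4 (beyond the scatter), taken as no change beyond the scatter but with wide uncertainty. For compound 4 in this assay the estimate is 95%, within a range from 60% to 125%.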

Compound 4, largest response reached (Emax), in percent of the reference or control that the assay uses: 53%
Beside the measured number, compound 4's estimate is 42 percentage points above it; the measured number lies below the stated range.
By their numbers in this assay, from the lowest: compounds 4 and 1 (each within the scatter of the next); then compound 2; then compound 3.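

At the aromatic carbon that had stayed the same in all earlier compounds, the change proves far from neutral in this assay: with the 5-propylpyrimidin-2-yl group held in place, the result is a number 54 percentage points lower from compound 3 to compound 4 (beyond the scatter). The maximal response therefore depends on this end of the shared core as well as on the group on the amine nitrogen. The two groups have the same counts of hydrogen-bond donors and acceptors, so those counts do not separate them, and no measurement at hand accounts for the difference.

The swap changes the ring, the fluorine and the methylsulfonyl group all at once, so the compounds shown do not assign the step to any one of them. Also open, as far as these compounds go, is how a plain phenyl, or a phenyl carrying a carboxylic acid or an amine, would behave at this position.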